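The source may hold more compounds than are shown below. What is called first, only, known or untested is meant among the compounds shown, and "the series" means these compounds.

Measured so far in a functional assay for agonist activity at Free fatty acid receptor 1 (Homo sapiens), read by FLIPR, in the presence of a further agent that is not named here; on this read-out lower numbers stand for an effect already at smaller amounts and higher numbers for an effect only at larger amounts of compound:
compound 1 `O=C1NC(=O)C(Cc2ccc(Oc3ccc(C(F)(F)F)cn3)cc2)S1` gives 558 nM
compound 2 `O=C1NC(=O)C(Cc2ccc(Oc3ccccc3)cc2)S1` gives 307 nM
compound 3 `Cc1cccc(Oc2ccc(CC3SC(=O)NC3=O)cc2)n1` gives 2620 nM

Compound 3 stands highest of the three numbers in this assay; its nearest neighbour is compound 1, its furthest compound 2. Among the measured compounds shown here, the one measured step, an 8.5-fold higher number from compound 2 to compound 3 (0.93 log units; beyond the scatter), shows that the 6-methylpyridin-2-yl group raised the number beyond the scatter. Compound 4 `O=C1NC(=O)C(Cc2ccc(Oc3ccc(Cl)cn3)cc2)S1` differs from compound 3 by 5-chloropyridin-2-yl in place of 6-methylpyridin-2-yl on an oxygen on an aromatic ring. For the measured compounds named here, no measured step bears directly on this change; compound 1, which carries a 5-trifluoromethylpyridin-2-yl group at the same place, sits far below compound 3 in this assay. Compound 4 is therefore expected to move by a 4.0-fold lower number from compound 3 to compound 4 (0.61 log units; beyond the scatter) back toward the region of compound 1. The estimate for compound 4 in this assay is 650 nM, with a range from 250 nM to 1700 nM.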

Compound 4, half-maximal effective concentration: 1870 nM
Beside the measured number, compound 4's estimate is 2.9-fold (0.46 log units) below it, and the stated range ends below it.
By their numbers in this assay, from the lowest: compounds 2 and 1 (each within the scatter of the next); then compounds 4 and 3 (each within the scatter of the next).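

In this assay the exchange of 6-methylpyridin-2-yl for 5-chloropyridin-2-yl gives a 1.4-fold lower number from compound 3 to compound 4 (0.15 log units; within the scatter) and so does not separate these two groups at this place. The phenyl group remains distinct from 5-chloropyridin-2-yl, with a 6.1-fold higher number from compound 2 to compound 4 (0.78 log units; beyond the scatter) on the oxygen, while the group on the pyridine also counts, as chloro in place of trifluoromethyl gives a 3.4-fold higher number from compound 1 to compound 4 (0.53 log units; beyond the scatter) on the aromatic carbon. Nothing available explains these steps. Still open, as far as these compounds go, is how 5-methoxypyridin-2-yl or 5-aminopyridin-2-yl would read here, and whether 6-chloropyridin-2-yl would match 5-chloropyridin-2-yl.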